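The source may hold more compounds than are shown below. What is called first, only, known or untested is meant among the compounds shown, and "the series" means these compounds.

Compound 1 `N/C(=N\NC(=S)N1CCSCC1)c1ccccn1`: 72.4%
Compound 2 `Cc1cccc(/C(N)=N/NC(=S)N2CCCC2)n1`: 61.8%

Going by the values given here, in a functional assay on MCF7 cells (Homo sapiens) for cytotoxicity, read by MTT assay, with a stated time of 72 h, tested at 100 uM (a lower number here means less inhibition of growth, a higher number more inhibition of growth at the concentration tested), compound 2 gives 61.8%, the lower of the two numbers measured so far. Its nearest neighbour is compound 1, which in this assay gives 72.4%, a number higher by a margin beyond the usual scatter of this kind of measurement.

Compound 3 `N/C(=N\NC(=S)N1CCCC1)c1ccccn1` has not yet been measured. It differs from compound 2 in a single place: hydrogen in place of methyl on an aromatic carbon. Among the compounds with values here, no pair of measured compounds shows this change on its own; compound 1 also carries hydrogen at that position but differs from compound 3 elsewhere, so its value can serve only as a loose guide.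

Given that compound 1, which lacks the methyl, sits higher than compound 2, compound 3 is expected to move upward, with a step estimated as a number 6.2 percentage points higher from compound 2 to compound 3 (within the scatter), modest and possibly not beyond the scatter. Compound 3 is estimated at 68%, with a range from 50% to 84%.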

Compound 3, percent growth inhibition at one concentration: 74.9%
Beside the measured number, compound 3's estimate is 6.9 percentage points below it; the measured number falls inside the stated range.
By their numbers in this assay, from the lowest: compound 2; then compounds 1 and 3 (each within the scatter of the next).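

In this assay, hydrogen in place of methyl on the aromatic carbon next to the ring nitrogen gives a number 13.1 percentage points higher from compound 2 to compound 3 (beyond the scatter) on an otherwise unchanged compound, so this change can now be read on its own and this position is shown to matter for the read-out. Pyrrolidin-1-yl in place of thiomorpholin-4-yl on the thiocarbonyl carbon gives a number 2.5 percentage points higher from compound 1 to compound 3 (within the scatter) when hydrogen occupies that aromatic carbon, so of these two single changes only the one at the aromatic carbon lies beyond the scatter. Nothing available gives a reason for the step at the methyl position.

As far as these compounds go, whether an ethyl, a methoxy or an amine on the same aromatic carbon would behave as the methyl does remains open. From the compounds shown here alone, it is also open whether the methyl gives a step of similar size when thiomorpholin-4-yl sits on the thiocarbonyl carbon.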